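A few compounds are considered here, and "the series" means these few. Any claim that something is new, unique, unknown or untested is made for them only; others in the source may bear on it.

Working notes on the series. Of the compounds shown here, two carry numbers so far. Compound 1 `O=C(Nc1cc2c(OCCC3CCCCN3)c(-c3ccc(Cl)c(Cl)c3)c(O)nc2cc1Cl)NC1CC1` gives, in a functional assay on cells (Pituitary gland cell) for antagonist activity at Gonadotropin-releasing hormone receptor (Rattus norvegicus) (a higher number here means a weaker inhibitor, a lower number a stronger inhibitor), 18 nM. Compound 2 `O=[N+]([O-])c1cc2c(OCCC3CCCCN3)c(-c3cccc(Cl)c3)c(O)nc2cc1Cl` gives in this assay 40 nM, the higher of the two numbers; its nearest neighbour is compound 1, whose number is lower by a gap that is beyond the usual scatter. The two compounds differ in more than one place, so their values are only compared as they stand.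

The next compound is compound 3 `O=[N+]([O-])c1cc2c(OCCC3CCCCN3)c(-c3cccs3)c(O)nc2cc1Cl`, not yet measured in this assay. It differs from compound 2 in a single place: thiophen-2-yl in place of 3-chlorophenyl on an aromatic carbon. Among the compounds with values here, no measured pair in the set shows this change, so the size of the step has to be estimated. A modest move towards a higher number is expected, with the step from compound 2 to compound 3 estimated at a 2.0-fold higher number from compound 2 to compound 3 (0.30 log units; within the scatter). For compound 3 the expected value in this assay is 80 nM, with a range from 25 nM to 250 nM.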

Compound 3, half-maximal inhibitory concentration: 220 nM
The estimate for compound 3 lay 2.8-fold (0.44 log units) below the measured number; low and high end bracket the measured number.
By their numbers in this assay, from the lowest: compound 1; then compound 2; then compound 3.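

On the aromatic carbon ortho to the 2-(piperidin-2-yl)ethoxy group and to the hydroxy group, the series now has its first single-place comparison: in this assay the change to thiophen-2-yl from 3-chlorophenyl gives a 5.5-fold higher number from compound 2 to compound 3 (0.74 log units; beyond the scatter) and so shows that the value depends on which aromatic group sits here. The two groups are not interchangeable at this position, although this rests on one pair only. No measurement at hand accounts for the step, and the chlorine, the ring size and the sulfur remain unseparated.

Open, from the compounds shown here alone, is where a plain phenyl or a thiophen-3-yl group would fall at this position relative to compound 2 and compound 3. Also open, going by these compounds, is whether the same step would hold with an amine in place of the nitro group on the shared core.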